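This account rests on a few compounds, and the source may have more. Where it says the series, first, only, none or still open, it means among the compounds named here.

Compound 1 `CCOC(=O)c1sc(-c2cccc(NC(=O)c3ccco3)c2)nc1Nc1ccc(N2CCN(C)CC2)cc1` is the starting point. In a functional assay on Ramos cells (Homo sapiens) for antiproliferative activity, read by CCK-8 assay, with a stated time of 72 h, tested at 40 uM (a lower number here means less inhibition, a higher number more inhibition at the concentration tested (going by the name of the read-out)), compound 1 gives 50.2%. Compound 2 `CCOC(=O)c1sc(-c2cccc(NC(=O)[C@H]3CC[C@H](C)CC3)c2)nc1Nc1ccc(N2CCN(C)CC2)cc1` carries one change, (4-methylcyclohexyl in place of furan-2-yl on a carbonyl carbon), and the step of a number 30.3 percentage points lower from compound 1 to compound 2 (beyond the scatter) brings compound 2 to 19.9%. Compound 3 `CN1CCN(c2ccc(Nc3nc(-c4cccc(NC(=O)c5ccco5)c4)sc3C(N)=O)cc2)CC1` keeps the whole of compound 1 apart from amino in place of ethoxy on a carbonyl carbon; the step of a number 46.5 percentage points higher from compound 1 to compound 3 (beyond the scatter) takes compound 3 to 96.7%, the highest of the three measured numbers.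

Compound 4 `CN1CCN(c2ccc(Nc3nc(-c4cccc(NC(=O)[C@H]5CC[C@H](C)CC5)c4)sc3C(N)=O)cc2)CC1` has not yet been measured. It differs from compound 3 by 4-methylcyclohexyl in place of furan-2-yl on a carbonyl carbon, the same change that led from compound 1 to compound 2, made at the same place. On the strength of a number 30.3 percentage points lower from compound 1 to compound 2 (beyond the scatter), a drop of a comparable size is expected, a number 31.7 percentage points lower from compound 3 to compound 4 (beyond the scatter), though the high starting value of compound 3 leaves room for the drop to be somewhat smaller or larger. Compound 4 is therefore estimated at 65% in this assay, likely between 35% and 92%.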

Compound 4, a percentage reported as inhibition, at one concentration (the size of the read-out at that concentration, not a potency): 55.1%
Estimate against measurement, compound 4: 9.9 percentage points above, within the range that was stated.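

In this assay, putting 4-methylcyclohexyl in place of furan-2-yl gives a number 41.6 percentage points lower from compound 3 to compound 4 (beyond the scatter) on the amide core, and this agrees with the same change on the core of compound 1: the same change on two cores in this assay, a number 30.3 percentage points lower (beyond the scatter) from compound 1 to compound 2 and a number 41.6 percentage points lower (beyond the scatter) from compound 3 to compound 4, 11.3 percentage points apart, within the scatter of two such steps. Putting amino in place of ethoxy gives a number 35.2 percentage points higher from compound 2 to compound 4 (beyond the scatter) with 4-methylcyclohexyl present, and this agrees with the same change made with furan-2-yl present: the same change on two cores in this assay, a number 46.5 percentage points higher (beyond the scatter) from compound 1 to compound 3 and a number 35.2 percentage points higher (beyond the scatter) from compound 2 to compound 4, 11.3 percentage points apart, within the scatter of two such steps. Each change therefore carried over between these two cores, but four compounds cannot show why, or whether it would hold on any other core in the series.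

From the compounds shown here alone, it remains open how a phenyl ring or a straight alkyl chain would behave in place of furan-2-yl. The same question stands for a hydroxyl or methylamino group in place of amino on that carbonyl carbon.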